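This account rests on a few compounds, and the source may have more. Where it says the series, first, only, none or still open, it means among the compounds named here.

Three compounds have been measured in an ADME assay on MT4 cells (Homo sapiens) for cytotoxicity, read by MTT assay, with a stated time of 5 days; on this read-out lower numbers stand for higher toxicity in this test and higher numbers for lower toxicity in this test:

Compound 1 `Cc1cc(C)cc(S(=O)(=O)c2c(C(=O)N[C@H]3CCN(Cc4cccnc4)C3)[nH]c3ccc(Cl)cc23)c1` gives 22800 nM.
Compound 2 `Cc1cc(C)cc(S(=O)(=O)c2c(C(=O)N[C@H]3CCN(Cc4ccccc4C#N)C3)[nH]c3ccc(Cl)cc23)c1` gives a limit of the assay, > 228000 nM.
Compound 3 `Cc1cc(C)cc(S(=O)(=O)c2c(C(=O)NC3CN(Cc4cccnc4)C3)[nH]c3ccc(Cl)cc23)c1` gives 36000 nM.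

All three share the same core and differ only in the group attached to the amide-type nitrogen. From compound 1 to compound 2 the change is 2-cyanophenyl in place of pyridin-3-yl on a saturated chain carbon bound to an amine nitrogen in a ring. That change gave an at least 10-fold higher number from compound 1 to compound 2 (1.00 log units; beyond the scatter). The value of compound 2 is a limit of the assay and not a number (the limit of > 228000 nM in this assay, at which 1 of the 3 values shown sits).

Compound 3 differs from compound 1 in the saturated ring that carries the amide-type nitrogen: 1-((pyridin-3-yl)methyl)azetidin-3-yl in place of 1-((pyridin-3-yl)methyl)pyrrolidin-3-yl on an amide-type nitrogen. Here a 1.6-fold higher number from compound 1 to compound 3 (0.20 log units; within the scatter), so compound 1 and compound 3 read as alike in this assay.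

Compound 4 `Cc1cc(C)cc(S(=O)(=O)c2c(C(=O)NC3CN(Cc4ccccc4C#N)C3)[nH]c3ccc(Cl)cc23)c1` has not yet been measured in this assay. It differs from compound 3 by 2-cyanophenyl in place of pyridin-3-yl on a saturated chain carbon bound to an amine nitrogen in a ring. This is the same change that turns compound 1 into compound 2, made at the same place, and it is now made on the core of compound 3. The step from compound 3 to compound 4 is expected to be a 6.9-fold higher number from compound 3 to compound 4 (0.84 log units; beyond the scatter), set beside the measured step of an at least 10-fold higher number from compound 1 to compound 2 (1.00 log units; beyond the scatter). That expectation rests on the earlier step of an at least 10-fold higher number from compound 1 to compound 2 (1.00 log units; beyond the scatter) and on compound 1 and compound 3 lying within the scatter of each other a 1.6-fold higher number from compound 1 to compound 3 (0.20 log units; within the scatter). For compound 4 the estimated value is 250000 nM, with a range from 90000 nM to 600000 nM, and a real chance that this assay again reports only a limit.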

Compound 4, half-maximal cytotoxic concentration: > 234000 nM
Compound 4 was reported as a limit; the forecaster's own chance of this, stated with the estimate: 65%; the middle value is on the limit's open side.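

Carried from one core to the other in this assay, the change from pyridin-3-yl to 2-cyanophenyl gives an at least 6.5-fold higher number from compound 3 to compound 4 (0.81 log units; beyond the scatter), which points toward lower toxicity in this test, as it did on the first core. Compound 4 gives > 234000 nM, which is a limit of the assay and not a number. The direction of the change therefore holds on both cores shown, but two cores are a small sample and the size of the step cannot be compared between them: the same change on two cores in this assay, an at least 10-fold higher number (1.00 log units; beyond the scatter) from compound 1 to compound 2 and an at least 6.5-fold higher number (0.81 log units; beyond the scatter) from compound 3 to compound 4; the limit leaves it open whether they differ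

The compounds shown leave open which part of the new group goes with the higher numbers, since a plain benzyl group without the nitrile, or a benzyl group carrying a methoxy group or a fluorine atom in place of the nitrile, would separate the nitrile from the carbon-only ring. They also leave open whether the change would act in the same way with a longer chain between the ring nitrogen and the aromatic ring, where a 2-phenylethyl group would be one example.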